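This account rests on a few compounds, and the source may have more. Where it says the series, first, only, none or still open, it means among the compounds named here.

Three compounds of this series share one core and end in a sulfonamide. In an assay on HEK293 cells for displacement of a labelled ligand from 5-hydroxytryptamine receptor 6 (Homo sapiens), with a stated time of 60 min, tested at 1 uM, in the presence of a further agent that is not named here (a higher number here means a stronger effect of the compound at the concentration tested, a lower number a weaker effect), compound 1 `COc1ccc(S(=O)(=O)N2CCC(CCC(=O)c3cc(Cl)c(N)cc3OC)CC2)cc1` is reported as "not active" (no number reported), and compound 3 `COc1ccc(S(=O)(=O)NCCCN2CCC(CCC(=O)c3cc(Cl)c(N)cc3OC)CC2)cc1` likewise as "not active" (no number reported). Among the measured compounds shown here, compound 2 `COc1cc(N)c(Cl)cc1C(=O)CCC1CCN(CCNS(=O)(=O)c2ccc(C)cc2)CC1` is the only member with a number: in this assay compound 2 gives 15%. Compound 4 `COc1cc(N)c(Cl)cc1C(=O)CCC1CCN(CCNS(=O)(=O)c2cc(Br)c(N)c(Br)c2)CC1` differs from compound 2 in one place: 4-amino-3,5-dibromophenyl in place of 4-methylphenyl on a sulfonyl sulfur. For the measured compounds named here, no step between measured compounds is available, so the weight of this change cannot be read from neighbours. Compound 2 reaches only 15%. Starting there, compound 4 is expected to stay in the same low region, with an expected step of a number 5 percentage points higher from compound 2 to compound 4 (within the scatter) that lies within the scatter. Compound 4 is estimated at 20%, in a range from 0% to 45%.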

Compound 4, a percentage reported as inhibition, at one concentration (the size of the read-out at that concentration, not a potency): 83%
For compound 4 the middle estimate is 63 percentage points below the measured one; the whole stated range lies below it.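

In this assay, 4-amino-3,5-dibromophenyl in place of 4-methylphenyl on a sulfonyl sulfur gives a number 68 percentage points higher from compound 2 to compound 4 (beyond the scatter), so this position can carry a large change in the read-out. The earlier compounds shown here, with little or no reported effect, gave no sign of this. No measurement shown here accounts for the step. On these data alone, it remains open whether the amino group alone or the two bromines alone would give such a step, and whether a carboxylic acid in place of that amino group would keep it.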